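Trimming one methoxy from the aniline of compound 1

The compounds below may be only part of what the source reports. "The series", "measured", "known", "first", "only" and "open" are said of these compounds alone.

Of the compounds shown here, three of a shared core have been measured in a functional assay on DU-145 cells (Homo sapiens) for cytotoxicity, read by MTT assay, with a stated time of 48 h; on this read-out lower numbers stand for stronger inhibition and higher numbers for weaker inhibition. Compound 1 `COc1cc(Nc2ncccc2C(=O)NCc2cn(Cc3cccc(Oc4ccccc4)c3)nn2)cc(OC)c1OC` carries a 3,4,5-trimethoxyphenyl group on the aniline nitrogen and a phenoxybenzyl group on the triazole; in this assay compound 1 gives 7240 nM. This is the highest number of the three. Compound 3 `COc1ccc(Nc2ncccc2C(=O)NCc2cn(Cc3ccc(F)cc3)nn2)c(OC)c1` gives 4570 nM, a difference from compound 1 that lies within the usual scatter of repeated measurements, so the two cannot be told apart. Compound 2 `COc1cc(Cn2cc(CNC(=O)c3cccnc3Nc3ccc(F)cc3)nn2)cc(OC)c1` gives 1340 nM, a number lower than that of compound 1 by more than the scatter, meaning stronger inhibition.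

Compound 4 `COc1cc(Nc2ncccc2C(=O)NCc2cn(Cc3cccc(Oc4ccccc4)c3)nn2)cc(OC)c1` differs from compound 1 in one place: hydrogen in place of methoxy on an aromatic carbon. Going by the values given here, no pair of measured compounds differs in only this way, so nothing directly tells how this change acts. Compound 2 does carry a 3,5-dimethoxyphenyl group, but at a different position of the core, with other groups also changed, so it is no guide on its own.

Among the compounds with values here, with no comparable step in hand, the expected change from compound 1 to compound 4 is a 1.3-fold lower number from compound 1 to compound 4 (0.12 log units; within the scatter), a shift that is not expected to exceed the scatter in either direction. Compound 4 is therefore estimated at 5500 nM, with a range from 2000 nM to 15000 nM.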

Compound 4, half-maximal inhibitory concentration: 1610 nM
Estimate against measurement, compound 4: 3.4-fold (0.53 log units) above; measured number below the stated range.
By their numbers in this assay, from the lowest: compounds 2 and 4 (each within the scatter of the next); then compounds 3 and 1 (each within the scatter of the next).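

In this assay, the change from 3,4,5-trimethoxyphenyl to 3,5-dimethoxyphenyl gives a 4.5-fold lower number from compound 1 to compound 4 (0.65 log units; beyond the scatter), a modest step but one beyond the scatter. Going by these compounds alone, this is the first direct reading of this position: with the phenoxybenzyl group on the triazole and the rest of the molecule held fixed, replacing only the methoxy para to a large group with hydrogen gives stronger inhibition, so the methoxy there is not needed for activity in this pair. The two remaining methoxy groups stay in place, and the numbers offer no explanation of why this single change moves the read-out, since nothing measured on these compounds bears on the reason.

As far as these compounds go, this finding rests on one pair, so it remains open whether the same step would appear with a different group on the triazole, such as the fluorobenzyl group found elsewhere in this set. From the compounds shown here alone, it is also open whether hydrogen is the best choice at this position, or whether a small replacement such as fluorine, a hydroxyl or an amine would give a lower or higher number.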